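Halogen swap on the shared core: bromo to fluoro

A few compounds are considered here, and "the series" means these few. Any claim that something is new, unique, unknown or untested is made for them only; others in the source may bear on it.

Three members of the series have been measured in a functional assay on MCF7 cells (Homo sapiens) for antiproliferative activity, read by MTT assay, with a stated time of 24 h; on this read-out lower numbers stand for stronger inhibition and higher numbers for weaker inhibition. Compound 1 `O=C(Nc1ccc2cc[nH]c2c1)c1ccc(Br)cc1` gives 38100 nM in this assay, the largest number of the three, though both others lie within the scatter of it: compound 3 `Cc1ccc(S(=O)(=O)Nc2ccc3cc[nH]c3c2)cc1` gives 37200 nM, and compound 2 `O=C(Nc1ccc2cc[nH]c2c1)c1cccc(C(F)(F)F)c1` gives 30600 nM. Within the data shown here, with all three within the scatter of one another, none can be called more or less active than the rest, and no step between measured compounds is available to calibrate what a change at a single position does on this core.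

Compound 4 `O=C(Nc1ccc2cc[nH]c2c1)c1ccc(F)cc1` differs from compound 1 by fluoro in place of bromo on an aromatic carbon. Among the measured compounds shown here, nothing measured so far speaks to a halogen exchange of this kind, and the numbers in hand occupy a narrow band. The step of a 1.0-fold higher number from compound 1 to compound 4 (0.02 log units; within the scatter) is therefore expected to be small, in no clear direction, and not beyond the scatter. Compound 4 is estimated at 40000 nM in this assay, with a range from 20000 nM to 80000 nM.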

Compound 4, half-maximal inhibitory concentration: 45900 nM
The estimate for compound 4 lay 1.1-fold (0.06 log units) below the measured number, and the stated range covers the measured number.
By their numbers in this assay, from the lowest: compounds 2, 3, 1 and 4 (each within the scatter of the next).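

Fluoro in place of bromo on an aromatic carbon, para to a large group, gives the first single-place step on the shared core in this assay: a 1.2-fold higher number from compound 1 to compound 4 (0.08 log units; within the scatter). At this position the exchange of one halogen for the other leaves the read-out within the scatter, so on this evidence bromo is not specifically required for the activity seen with compound 1. Nothing on hand bears on the reason for this outcome.

The compounds shown compare only these two halogens at this position, so it remains open whether an amine, a carboxylic acid or a methoxy group there would give a step beyond the scatter. Also open, going by these compounds, is how the core reads with plain hydrogen in this place.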